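Phenyl to 4-chlorophenyl: expected growth inhibition for compound 3

The source may hold more compounds than are shown below. What is called first, only, known or untested is meant among the compounds shown, and "the series" means these compounds.

Measured compounds:
Compound 1 `COC(=O)c1nnn([C@@H]2C(=O)N(c3ccc(C)cc3)[C@@H]2/C=C/c2ccccc2)c1C(=O)OC` — in a functional assay on KB cells (Homo sapiens) for inhibition, tested at 10 uM (on this read-out higher numbers stand for more inhibition of growth at the one concentration tested and lower numbers for less inhibition of growth), compound 1 shows "not determined" (no result reported).
Compound 2 `O=C1[C@@H](n2cc(-c3ccccc3)nn2)[C@@H](/C=C/c2ccccc2)N1c1ccccc1` — in this assay compound 2 gives 10%.

Among the compounds with values here, compound 2 holds the only number in this assay; compound 1 has no result there, so no step between measured compounds can be drawn. Compound 3 `O=C1[C@@H](n2cc(-c3ccccc3)nn2)[C@@H](/C=C/c2ccccc2)N1c1ccc(Cl)cc1` differs from compound 2 by chloro in place of hydrogen on an aromatic carbon. With nothing measured on this change, a step of a number 5 percentage points higher from compound 2 to compound 3 (within the scatter) in this assay is expected, no larger than the usual scatter. Compound 3 is estimated at 15%, within 0% to 35%.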

Compound 3, percent growth inhibition at one concentration: 16.8%
For compound 3 the middle estimate is 1.8 percentage points below the measured one; the range from low to high includes it.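

In this assay, this position now has its first readable step, a number 6.8 percentage points higher from compound 2 to compound 3 (within the scatter), so chloro in place of hydrogen on this aromatic carbon, para to a large group, does not separate the two compounds. Both compounds stay in the same band of the read-out at the one concentration tested. No supporting data bear on this result.

On these data alone, whether an amine, a carboxylic acid or a methoxy group at this place would give a step beyond the scatter remains open. Also open, as far as these compounds go, is how chloro would read elsewhere on this ring.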